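From Isobutyl to 3-Methoxyphenyl on Nitrogen

The compounds below may be only part of what the source reports. "The series", "measured", "known", "first", "only" and "open" are said of these compounds alone.

Compound 1 (`COc1cc(-c2nccn2CC(C)C)cc(OC)c1OC`) is the starting point in a functional assay on HeLa cells (Homo sapiens) for antiproliferative activity, read by MTT assay, with a stated time of 72 h; on this read-out higher numbers stand for weaker inhibition and lower numbers for stronger inhibition. Here compound 1 gives > 100000 nM, which is a limit and not a number. Compound 1 thus stands at the limit of > 100000 nM in this assay, at which 2 of the 3 values shown sit. Compound 2 (`COc1cc(-c2nccn2S(=O)(=O)c2ccccc2)cc(OC)c1OC`) gives > 100000 nM, which is also a limit. Going by the values given here, the only true number so far belongs to compound 3 (`COc1cc(-c2nccn2-c2ccc3cc[nH]c3c2)cc(OC)c1OC`), which gives 4800 nM.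

Compound 4 (`COc1cccc(-n2ccnc2-c2cc(OC)c(OC)c(OC)c2)c1`) differs from compound 1 by one change, 3-methoxyphenyl in place of isobutyl on an aromatic nitrogen. Compound 3 also has an aromatic group on that nitrogen, and its 4800 nM points towards stronger inhibition for compound 4 than for compound 1. Compound 2 goes against any simple rule, since it too carries a group with a ring there and still sits at its limit. The expected change is an at least 8.3-fold lower number from compound 1 to compound 4 (0.92 log units; beyond the scatter), towards stronger inhibition and beyond the scatter. For compound 4 the estimated value is 12000 nM, with an expected range from 2000 nM to 70000 nM.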

Compound 4, half-maximal inhibitory concentration: 11000 nM
The estimate for compound 4 lay 1.1-fold (0.04 log units) above the measured number; measured number inside the range.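

Replacing isobutyl with 3-methoxyphenyl on the aromatic nitrogen gives an at least 9.0-fold lower number from compound 1 to compound 4 (0.95 log units; beyond the scatter) in this assay, so a single change at this position is enough to move the read-out from a limit to a true number. The size of this step has only a lower end, since compound 1 stands at a limit and not a number: the limit of > 100000 nM in this assay, at which 2 of the 4 values shown sit.

Compound 4 joins compound 3 as a second compound with an aromatic group on that nitrogen and a true number, while compound 2, which also has a ring in its group there, goes against any rule based on a ring alone.

Open, from the compounds shown here alone, is how much of the step belongs to the ring and how much to its methoxy group, a split that a plain phenyl on this nitrogen would show. Also open, going by these compounds, is how an amine or a carboxylic acid on that ring would read in this assay.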